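Working notes on compound 4, the nitro variant of compound 2

The source may hold more compounds than are shown below. What is called first, only, known or untested is meant among the compounds shown, and "the series" means these compounds.

Measured compounds:
compound 1 `O=C(CSc1nc(Nc2ccccc2)c2ccccc2n1)Nc1ccccc1Br` — 19800 nM
compound 2 `C=CC(=O)Nc1cccc(NC(=O)CSc2nc(Nc3ccccc3)c3ccccc3n2)c1` — 8740 nM
compound 3 `O=C(CSc1nc(Nc2ccccc2)c2ccccc2n1)Nc1ccc(Cl)cc1Cl` — 9110 nM

In a functional assay on PC-3 cells (Homo sapiens) for inhibition, read by MTT assay, with a stated time of 72 h (a higher number here means a weaker inhibitor, a lower number a stronger inhibitor), compound 2 gives 8740 nM, the lowest of the three numbers. Its neighbour compound 3 gives 9110 nM, and the gap between them, a 1.0-fold higher number from compound 2 to compound 3 (0.02 log units; within the scatter), is within the scatter, so no order between compound 2 and compound 3 is claimed. Compound 1 stands apart: a 2.3-fold lower number from compound 1 to compound 2 (0.36 log units; beyond the scatter) and a 2.2-fold lower number from compound 1 to compound 3 (0.34 log units; beyond the scatter) are both modest steps beyond the scatter.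

All three measured steps change the aryl group on the amide-type nitrogen. None touches the anilino ring, which stays unsubstituted phenyl in compound 1, compound 2 and compound 3.

Compound 4 `C=CC(=O)Nc1cccc(NC(=O)CSc2nc(Nc3cccc([N+](=O)[O-])c3)c3ccccc3n2)c1` differs from compound 2 by nitro in place of hydrogen on an aromatic carbon. For the measured compounds named here, no measured step bears on this change; the measured steps only show that changes on the other aryl group move this assay by modest amounts at most. Lacking a comparable precedent, no step beyond the scatter is expected in this assay.

Compound 4 is therefore estimated at 8500 nM, with a range from 3000 nM to 25000 nM. This estimate means a 1.0-fold lower number from compound 2 to compound 4 (0.01 log units; within the scatter), an expected step within the scatter.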

Compound 4, half-maximal inhibitory concentration: 46300 nM
The estimate for compound 4 lay 5.4-fold (0.74 log units) below the measured number; the measured number lies above the stated range.
By their numbers in this assay, from the lowest: compounds 2 and 3 (each within the scatter of the next); then compound 1; then compound 4.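

In this assay the anilino ring proves not to be a neutral place: nitro in place of hydrogen on an aromatic carbon, turning anilino into (3-nitrophenyl)amino, gives a 5.3-fold higher number from compound 2 to compound 4 (0.72 log units; beyond the scatter) and so a weaker inhibitor. The earlier compounds shown here varied only the aryl group on the amide-type nitrogen, and this first change on the other ring moves the number further than either a 2.3-fold lower number from compound 1 to compound 2 (0.36 log units; beyond the scatter) or a 2.2-fold lower number from compound 1 to compound 3 (0.34 log units; beyond the scatter) does. Nothing at hand explains the step.

Open, going by these compounds, is whether the shift belongs to nitro itself or would follow any group at this carbon, which an amine or a methoxy group there would help to separate. Also open, on these data alone, is whether nitro on the same ring carries the same step when paired with the 2,4-dichlorophenyl group of compound 3.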